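Compound 4 from compound 3: loss of the chloro group

A few compounds are considered here, and "the series" means these few. Any claim that something is new, unique, unknown or untested is made for them only; others in the source may bear on it.

The series shares one core and varies the group on the saturated chain carbon bound to a sulfur. Compound 1 `Cc1cc(N2CC[C@@H](C)[C@@H](N(C)c3ncnc4[nH]ccc34)C2)n2nc(SCc3ccc(C(F)(F)F)cc3)nc2n1` carries 4-(trifluoromethyl)phenyl there and in a functional assay on HGC-27 cells (Homo sapiens) for inhibition, read by MTT assay, with a stated time of 72 h (a higher number here means a weaker inhibitor, a lower number a stronger inhibitor), compound 1 gives 9540 nM. Compound 2 `Cc1cc(N2CC[C@@H](C)[C@@H](N(C)c3ncnc4[nH]ccc34)C2)n2nc(SCc3cc(Cl)ccc3Cl)nc2n1` carries 2,5-dichlorophenyl, and in this assay compound 2 gives 19200 nM, the step being a 2.0-fold higher number from compound 1 to compound 2 (0.30 log units; within the scatter). Compound 3 `Cc1cc(N2CC[C@@H](C)[C@@H](N(C)c3ncnc4[nH]ccc34)C2)n2nc(SCc3ccc(F)c(Cl)c3)nc2n1` carries 3-chloro-4-fluorophenyl. In this assay, among the compounds with values here, compound 3 returns only a limit, > 100000 nM, so it is the one value sitting at the limit of > 100000 nM in this assay, at which 1 of the 3 values shown sits. The steps of an at least 10-fold higher number from compound 1 to compound 3 (1.02 log units; beyond the scatter) and an at least 5.2-fold higher number from compound 2 to compound 3 (0.71 log units; beyond the scatter) set compound 3 well apart from the other two, at the weak end of what has been measured.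

Compound 4 `Cc1cc(N2CC[C@@H](C)[C@@H](N(C)c3ncnc4[nH]ccc34)C2)n2nc(SCc3ccc(F)cc3)nc2n1` differs from compound 3 by hydrogen in place of chloro on an aromatic carbon. Within the data shown here, no measured step removes a chloro on its own; the two steps into compound 3 show only that the 3-chloro-4-fluorophenyl group sits far weaker than either other group. Removing the chloro is expected to pull the number back down, though the size is uncertain and a limit remains possible. Compound 4 is expected at 40000 nM, within 10000 nM to 150000 nM, the expected step being an at least 2.5-fold lower number from compound 3 to compound 4 (0.39 log units; beyond the scatter).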

Compound 4, half-maximal inhibitory concentration: 26000 nM
Beside the measured number, compound 4's estimate is 1.5-fold (0.19 log units) above it, and the stated range covers the measured number.
By their numbers in this assay, from the lowest: compounds 1, 2 and 4 (each within the scatter of the next, the first and the last beyond it). At a limit, above all of these: compound 3.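

In this assay, hydrogen in place of the chloro alone gives an at least 3.8-fold lower number from compound 3 to compound 4 (0.58 log units; beyond the scatter), so the large gap seen for the 3-chloro-4-fluorophenyl group rests on that one chloro, not on the 4-fluorobenzyl part it keeps. The 4-fluorophenyl group reads level with 2,5-dichlorophenyl, a 1.4-fold higher number from compound 2 to compound 4 (0.13 log units; within the scatter), whereas fluoro in place of trifluoromethyl gives a 2.7-fold higher number from compound 1 to compound 4 (0.44 log units; beyond the scatter), so the para-free comparison among the measurable groups stays narrow. Compound 3 remains a limit, so the true size of the chloro step stays unfixed: the limit of > 100000 nM in this assay, at which 1 of the 4 values shown sits.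

On these data alone, whether a chloro weakens the series only when it shares the ring with a fluoro remains open, and a 3-chlorophenyl group would test this. As far as these compounds go, how an amine or a carboxylic acid on this ring would read in this assay is also open.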